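Aryl group variation on the ring nitrogen: flat inhibition

A few compounds are considered here, and "the series" means these few. Any claim that something is new, unique, unknown or untested is made for them only; others in the source may bear on it.

On the numbers shown, compound 3 `Nc1scc(CN2CCN(c3cc(F)cc(F)c3)CC2)c1C(=O)c1ccc(Cl)cc1` holds the lowest figure in an assay on CHO cells for displacement of a labelled ligand from adenosine receptor A1 (Homo sapiens), read by scintillation counting, with a stated time of 120 min, tested at 10 uM (a higher number here means more inhibition at the concentration tested (going by the name of the read-out), a lower number less inhibition), where compound 3 gives 0%. Compound 1 `Nc1scc(CN2CCN(c3ccc([N+](=O)[O-])cc3)CC2)c1C(=O)c1ccc(Cl)cc1` gives 1% and compound 2 `Nc1scc(CN2CCN(c3cccc4ccccc34)CC2)c1C(=O)c1ccc(Cl)cc1` gives 1%, and the gaps are small: a number 1 percentage points lower from compound 1 to compound 3 (within the scatter), a number 1 percentage points lower from compound 2 to compound 3 (within the scatter). Compound 4 `Nc1scc(CN2CCN(c3ccc(F)c(Cl)c3)CC2)c1C(=O)c1ccc(Cl)cc1` differs from compound 3 by 3-chloro-4-fluorophenyl in place of 3,5-difluorophenyl on an amine nitrogen in a ring. Among the compounds with values here, the steps that bear on this change are the earlier swaps of the group on the amine nitrogen in the ring: no change at the digits printed from compound 1 to compound 2 (within the scatter), a number 1 percentage points lower from compound 1 to compound 3 (within the scatter) and a number 1 percentage points lower from compound 2 to compound 3 (within the scatter), none beyond the scatter. No step beyond the scatter is therefore expected in this assay, the estimated step being a number 1 percentage points higher from compound 3 to compound 4 (within the scatter). Compound 4 is expected to give 1%, with a range from -4% to 8%.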

Compound 4, a percentage reported as inhibition, at one concentration (the size of the read-out at that concentration, not a potency): 0%
Beside the measured number, compound 4's estimate is 1 percentage points above it; measured number inside the range.
By their numbers in this assay, from the lowest: compounds 3, 4, 1 and 2 (each within the scatter of the next).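

Chlorine on the aryl group at the amine nitrogen is new at this position, and in this assay it gives no change at the digits printed from compound 3 to compound 4 (within the scatter) with no shift in the flat picture. The comparison with the two other aryl groups agrees, showing a number 1 percentage points lower from compound 2 to compound 4 (within the scatter) and a number 1 percentage points lower from compound 1 to compound 4 (within the scatter) across a nitro group and a naphthalene. Nothing available explains this flatness.

Going by these compounds, all four compounds carry an aryl group on this nitrogen, so a non-aryl group there, such as a longer alkyl chain or one ending in a carboxylic acid, remains open. On these data alone, whether any group at this position can raise the inhibition also remains open.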